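Methyl-to-ethyl step on the pyrazole nitrogen

This account rests on a few compounds, and the source may have more. Where it says the series, first, only, none or still open, it means among the compounds named here.

Measured compounds in a functional assay on CHO-K1 cells for antagonist activity at prostaglandin E2 receptor EP1 subtype (Homo sapiens), read by FLIPR and calcium flux; on this read-out higher numbers stand for weaker inhibition and lower numbers for stronger inhibition:
compound 1 `Cc1ccc(S(=O)(=O)N(CC(=O)NCc2ccc(Cl)cc2)c2ccccn2)cc1`: < 1450 nM
compound 2 `Cc1ccc(S(=O)(=O)N(CC(=O)NCc2ccc(Cl)cc2)c2ncccc2C)cc1`: < 1450 nM
compound 3 `Cc1ccc(S(=O)(=O)N(CC(=O)NCc2ccc(Cl)cc2)c2ccnn2C)cc1`: 589 nM

Going by the values given here, compound 3 `Cc1ccc(S(=O)(=O)N(CC(=O)NCc2ccc(Cl)cc2)c2ccnn2C)cc1` is the one compound of the three that gives a number in this assay, namely 589 nM. Compound 1 gives only a limit of the assay, < 1450 nM. Compound 2 likewise gives only a limit, < 1450 nM. Two of the three values therefore sit at a limit (the limit of < 1450 nM in this assay, at which 2 of the 3 values shown sit), and none of the three steps can be sized: a step that the two limits leave unreadable from compound 1 to compound 2, a step that the limit leaves unreadable from compound 1 to compound 3 and a step that the limit leaves unreadable from compound 2 to compound 3 are all unreadable.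

Compound 4 `CCn1nccc1N(CC(=O)NCc1ccc(Cl)cc1)S(=O)(=O)c1ccc(C)cc1` differs from compound 3 by methyl in place of hydrogen on a saturated chain carbon bound to an aromatic nitrogen, which, read one bond further out, is methyl to ethyl on the 1-methyl-1H-pyrazol-5-yl group. Among the compounds with values here, no measured step touches this position, and the measured steps give no readable size at all, so nothing among them bears on the change. The expected step of a 1.0-fold higher number from compound 3 to compound 4 (0.01 log units; within the scatter) is therefore none beyond the scatter, in no particular direction. Compound 4 is estimated at 600 nM, within 200 nM to 1800 nM.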

Compound 4, inhibition constant: 72.4 nM
Compound 4: middle estimate off by 8.3-fold (0.92 log units), on the high side, outside the stated range (below it).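

In this assay, going by these compounds alone, the pyrazole nitrogen is the first position to give a readable step: going from methyl to ethyl gives an 8.1-fold lower number from compound 3 to compound 4 (0.91 log units; beyond the scatter). This position therefore responds strongly to a small change, with one added carbon on a saturated chain carbon bound to an aromatic nitrogen moving inhibition well beyond the scatter. The steps from compound 1 and compound 2 to compound 4 cannot be read, so the 1-ethyl-1H-pyrazol-5-yl group cannot be sized against either pyridine-bearing compound: the limit of < 1450 nM in this assay, at which 2 of the 4 values shown sit.

The compounds shown leave open whether the trend continues to a longer chain such as n-propyl or to a branched isopropyl group. They also do not show whether a chain ending in a hydroxyl or an amine would be tolerated on this nitrogen.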